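Swapping the Halogenated Benzyl Arm of Compound 2

A few compounds are considered here, and "the series" means these few. Any claim that something is new, unique, unknown or untested is made for them only; others in the source may bear on it.

Compound 2 `Cc1cc(Nc2cc(-c3ccccc3)[nH]n2)n2nc(SCc3c(Cl)cccc3Cl)nc2n1` gives 3230 nM in a functional assay on MCF7 cells (Homo sapiens) for inhibition, read by MTT assay, with a stated time of 72 h; on this read-out higher numbers stand for weaker inhibition and lower numbers for stronger inhibition. Among the three measured compounds it holds the second highest number, with compound 1 `Cc1cc(Nc2cc(-c3ccccc3)[nH]n2)n2nc(SCCc3ccccc3)nc2n1` nearest at 2700 nM and compound 3 `Cc1cc(Nc2ccn(Cc3cccc4ccccc34)n2)n2nc(SCc3ccc(Br)cc3)nc2n1` furthest at 4310 nM; both gaps lie within the scatter. Compound 4 `Cc1cc(Nc2cc(-c3ccccc3)[nH]n2)n2nc(SCc3ccccc3Br)nc2n1` differs from compound 2 in one place: 2-bromophenyl in place of 2,6-dichlorophenyl on a saturated chain carbon bound to a sulfur. Among the measured compounds shown here, the only measured step at this same place, a 1.2-fold higher number from compound 1 to compound 2 (0.08 log units; within the scatter), stayed within the scatter, so exchanging the group on the saturated chain carbon bound to a sulfur has so far moved nothing. A step of a 1.1-fold lower number from compound 2 to compound 4 (0.03 log units; within the scatter) is therefore expected, nothing beyond the scatter. Compound 4 is estimated to give 3000 nM in this assay, within a range from 1500 nM to 6000 nM.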

Compound 4, half-maximal inhibitory concentration: 3020 nM
Estimate against measurement, compound 4: 1.0-fold (0.00 log units) below; the measured number falls inside the stated range.
By their numbers in this assay, from the lowest: compounds 1, 4, 2 and 3 (each within the scatter of the next).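

In this assay the change from 2,6-dichlorophenyl to 2-bromophenyl on a saturated chain carbon bound to a sulfur gives a 1.1-fold lower number from compound 2 to compound 4 (0.03 log units; within the scatter) and the change from benzyl to 2-bromophenyl gives a 1.1-fold higher number from compound 1 to compound 4 (0.05 log units; within the scatter). This place has now taken two chlorines, one bromine and no halogen on the aromatic ring without any step leaving the scatter. Nothing at hand explains this flat result.

From the compounds shown here alone, whether an amine or a carboxylic acid on that chain carbon would produce a step beyond the scatter remains open.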